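A few compounds are considered here, and "the series" means these few. Any claim that something is new, unique, unknown or untested is made for them only; others in the source may bear on it.

Measured so far:
compound 1 `CCc1ccccc1-n1nncc1CN1C(=O)C2(C(C#N)=C(N)Oc3c(N)cc4nc5ccccc5nc4c32)c2ccccc21`, in an ADME assay on L02 cells (Homo sapiens) for antiproliferative activity, read by MTT assay, with a stated time of 48 h; a higher number here means a weaker inhibitor, a lower number a stronger inhibitor: 22900 nM
compound 2 `Cc1cc(C)cc(-n2nncc2CN2C(=O)C3(C(C#N)=C(N)Oc4c(N)cc5nc6ccccc6nc5c43)c3ccccc32)c1`, in this assay: > 50000 nM

Compound 2 gives only a limit in this assay, (the limit of > 50000 nM in this assay, at which 1 of the 2 values shown sits), so no number is known for it. Going by the values given here, the single measured step, an at least 2.1-fold higher number from compound 1 to compound 2 (0.33 log units; beyond the scatter), ran toward a weaker inhibitor. Compound 3 `CCc1cccc(CC)c1-n1nncc1CN1C(=O)C2(C(C#N)=C(N)Oc3c(N)cc4nc5ccccc5nc4c32)c2ccccc21` differs from compound 2 in one place: 2,6-diethylphenyl in place of 3,5-dimethylphenyl on an aromatic nitrogen. Among the compounds with values here, only that measured step bears on this change, and it too exchanged the group on the aromatic nitrogen, but it went from 2-ethylphenyl to 3,5-dimethylphenyl, whereas here 2,6-diethylphenyl enters. Nothing measured shows how a 2,6-diethylphenyl group behaves here. Compound 3 is therefore expected to stay near the limit, with an expected step of an at least 1.2-fold lower number from compound 2 to compound 3 (0.09 log units; that floor lies within the scatter) that lies within the scatter. Compound 3 is estimated at 40000 nM, within a range from 12000 nM to 100000 nM.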

Compound 3, half-maximal inhibitory concentration: > 50000 nM
Compound 3 gave a limit, no number; the forecaster's own chance of this, stated with the estimate: 45%; at least 1.2-fold (0.09 log units) between middle value and limit.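

Ethyl in place of hydrogen on an aromatic carbon, which turns 2-ethylphenyl into 2,6-diethylphenyl, gives an at least 2.1-fold higher number from compound 1 to compound 3 (0.33 log units; beyond the scatter), a move toward a weaker inhibitor in this assay. Compound 3 gives only a limit, > 50000 nM, and not a number. The step between compound 2 and compound 3 cannot be read, since neither has a number: the limit of > 50000 nM in this assay, at which 2 of the 3 values shown sit.

Compound 1 is thus the only compound shown with a number, and how far compound 2 and compound 3 lie past the limit stays unknown. Also open, on these data alone, is how this position responds to a group of another kind on the phenyl ring, such as an amine or a carboxylic acid, or to a longer chain in place of ethyl.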